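From benzylamino to cyclohexylamino: a step still unmeasured

This account rests on a few compounds, and the source may have more. Where it says the series, first, only, none or still open, it means among the compounds named here.

Among the compounds with values here, in a functional assay on a cell-free system (Platelet, plasma, Homo sapiens) for inhibition, with stated times of 1 min and 3 min (a higher number here means a weaker inhibitor, a lower number a stronger inhibitor), only two compounds of this small set carry a number. Compound 3 `CCSc1nc(NCc2ccccc2)c2ncn([C@@H]3O[C@H](CO)[C@@H](O)[C@H]3O)c2n1` stands at 176000 nM and compound 1 `CC(C)Sc1nc(NC2CCCCC2)c2ncn([C@@H]3O[C@H](CO)[C@@H](O)[C@H]3O)c2n1` at 187000 nM so the two lie within the usual scatter of each other, and neither can be ranked ahead. Compound 2 `CCCCN(CCCC)c1nc(SCC)nc2c1ncn2[C@@H]1O[C@H](CO)[C@@H](O)[C@H]1O` has "not determined" (no result reported) as its entry.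

Compound 4 `CCSc1nc(NC2CCCCC2)c2ncn([C@@H]3O[C@H](CO)[C@@H](O)[C@H]3O)c2n1` has not yet been measured. It departs from compound 3 by a single change: cyclohexyl in place of benzyl on a nitrogen on an aromatic ring. Within the data shown here, no measured pair in the set shows the size of a step of this kind, so the data give no direct guide to it. With compound 3 at 176000 nM and no evidence pointing either way, no step beyond the scatter is expected in this assay in either direction. The estimated move is a 1.0-fold higher number from compound 3 to compound 4 (0.01 log units; within the scatter) and would remain within the scatter. Compound 4 is expected at 180000 nM with 90000 nM to 350000 nM as its estimated range.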

Compound 4, half-maximal inhibitory concentration: 104000 nM
Compound 4: the middle estimate sits 1.7-fold (0.24 log units) above what was measured; low and high end bracket the measured number.
By their numbers in this assay, from the lowest: compounds 4, 3 and 1 (each within the scatter of the next).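

In this assay, within the data shown here, the change of benzyl to cyclohexyl on a nitrogen on an aromatic ring now has a measured size, a 1.7-fold lower number from compound 3 to compound 4 (0.23 log units; within the scatter), a step the earlier compounds could not show. Among these compounds, compound 4 also gives a first reading of a second place, where hydrogen in place of methyl on a saturated chain carbon bound to a saturated chain carbon and a sulfur gives a 1.8-fold lower number from compound 1 to compound 4 (0.25 log units; within the scatter), so neither change separates its pair beyond the scatter. Nothing available explains the size of either step.

As far as these compounds go, whether a smaller ring such as cyclopentyl on that nitrogen would give a step beyond the scatter remains open. The same holds for a longer chain such as hexyl on the sulfur, and for a basic amine added to the cyclohexyl ring.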